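The compounds below may be only part of what the source reports. "The series", "measured", "known", "first", "only" and "open" are said of these compounds alone.

Of the two numbers in hand, compound 2 `O=S(=O)(NCCCNCc1cccc2ccccc12)c1cc(C(F)(F)F)cc(C(F)(F)F)c1` stands lowest: in a functional assay on ASPC1 cells (Homo sapiens) for inhibition, read by MTT assay, with a stated time of 72 h (on this read-out higher numbers stand for weaker inhibition of growth and lower numbers for stronger inhibition of growth), compound 2 gives 21000 nM, whereas compound 1 `CN(CCCNS(=O)(=O)c1cc(C(F)(F)F)cc(C(F)(F)F)c1)Cc1ccccc1` gives 51000 nM, a gap beyond the scatter. Within the data shown here, compound 3 `COc1cccc(CNCCCNS(=O)(=O)c2cc(C(F)(F)F)cc(C(F)(F)F)c2)c1` differs from compound 2 by 3-methoxyphenyl in place of naphthalen-1-yl on a saturated chain carbon bound to an amine nitrogen, a change for which no step between measured compounds exists. Compound 3 is expected to show a step of a 1.9-fold higher number from compound 2 to compound 3 (0.28 log units; within the scatter) toward weaker inhibition of growth, because compound 1 gives 51000 nM. In this assay compound 3 is therefore estimated at 40000 nM, with a range from 15000 nM to 100000 nM.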

Compound 3, concentration for 50% growth inhibition: 3800 nM
Compound 3: middle estimate off by 11-fold (1.02 log units), on the high side; measured number below the stated range.
By their numbers in this assay, from the lowest: compound 3; then compound 2; then compound 1.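

In this assay, 3-methoxybenzyl in place of (naphthalen-1-yl)methyl gives a 5.5-fold lower number from compound 2 to compound 3 (0.74 log units; beyond the scatter), so the second aromatic ring of the naphthalen-1-yl group is not needed for a low number at this place. Replacing the benzyl(methyl)amino group with (3-methoxybenzyl)amino gives a 13-fold lower number from compound 1 to compound 3 (1.13 log units; beyond the scatter), the largest step seen so far. No measurement at hand accounts for either step. The compounds shown leave open whether the methoxy group itself matters, which an unsubstituted benzylamino group would test. As far as these compounds go, how a 3-chlorobenzyl group or a longer chain would fare also remains open.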